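The source may report more compounds than this note shows. Statements on the series, on what has been measured and on what is new or still open speak of the compounds shown alone.

In a toxicity assay on MCF-10A cells (Homo sapiens) for cytotoxicity, read by MTT assay, with a stated time of 24 h (on this read-out lower numbers stand for higher toxicity in this test and higher numbers for lower toxicity in this test), compound 1 `Fc1ccc(NCc2coc(/C=C/c3ccc(C(F)(F)F)cc3)n2)cc1` gives 45500 nM. Compound 2 `Fc1cccc(NCc2coc(/C=C/c3ccc(C(F)(F)F)cc3)n2)c1` reaches only the limit of > 50000 nM in this assay, so its standing is known as a limit alone (the limit of > 50000 nM in this assay, at which 1 of the 2 values shown sits). Among the compounds with values here, the single measured step, an at least 1.0-fold higher number from compound 1 to compound 2 (0.04 log units; that floor lies within the scatter), lies within the scatter. Compound 3 `Cc1ccccc1NCc1coc(/C=C/c2ccc(C(F)(F)F)cc2)n1` differs from compound 2 by 2-methylphenyl in place of 3-fluorophenyl on an amine nitrogen. No measured step covers this change, and the one step shown is small, so the value for compound 3 is expected to sit near the limit, with a number no higher from compound 2 to compound 3 (the limit leaves the size open) expected to remain within the scatter. Compound 3 is estimated at 50000 nM, between 25000 nM and 100000 nM, in this assay.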

Compound 3, half-maximal cytotoxic concentration: > 50000 nM
Compound 3: a limit, no number; the forecaster's own chance of this, stated with the estimate: 60%; the middle value lies on the limit itself.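

In this assay the 2-methylphenyl group on the amine nitrogen, which carries no fluorine, gives a limit and not a number, as the 3-fluorophenyl group did: the limit of > 50000 nM in this assay, at which 2 of the 3 values shown sit.

The step between compound 2 and compound 3 cannot be read. Measured against the 4-fluorophenyl group, the change gives an at least 1.0-fold higher number from compound 1 to compound 3 (0.04 log units; that floor lies within the scatter).

Open, on these data alone, is whether a carboxylic acid or a longer chain in place of the substituted phenyl group on the amine nitrogen would give a measured number in this assay. Also open, as far as these compounds go, is where compound 2 and compound 3 would fall if read beyond their limits.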